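The source may report more compounds than this note shows. Statements on the series, on what has been measured and on what is new or still open speak of the compounds shown alone.

Working notes on the sulfamate series. In an assay on HEK293 cells for inhibition of Steryl-sulfatase (Homo sapiens), tested at 1 uM (on this read-out lower numbers stand for a weaker effect and higher numbers for a stronger effect at the one concentration tested), compound 1 `CCN(Cc1ccccc1)c1cccc(C(=O)N2CCc3ccc(OS(N)(=O)=O)cc3C2)c1` gives 69% and compound 2 `CCCN(Cc1ccccc1)c1cccc(C(=O)N2CCc3ccc(OS(N)(=O)=O)cc3C2)c1` gives 67.4%; the step of a number 1.6 percentage points lower from compound 1 to compound 2 (within the scatter) leaves compound 2 within the scatter of compound 1, so nothing separates the two. Compound 3 `NS(=O)(=O)Oc1ccc2c(c1)CN(C(=O)c1cccc(N(CCCO)Cc3ccccc3)c1)CC2` differs from compound 2 by hydroxy in place of hydrogen on a saturated chain carbon, three bonds along the chain from a nitrogen on an aromatic ring. For the measured compounds named here, the only measured step, from compound 1 to compound 2, alters the same chain without effect beyond the scatter; no step with a hydroxy enters the data. Compound 3 is therefore expected to give 63% (range 42% to 80%), a step of a number 4.4 percentage points lower from compound 2 to compound 3 (within the scatter) estimated not beyond the scatter.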

Compound 3, a percentage reported as inhibition, at one concentration (the size of the read-out at that concentration, not a potency): 37.3%
Compound 3: middle estimate off by 25.7 percentage points, on the high side, outside the stated range (below it).
By their numbers in this assay, from the lowest: compound 3; then compounds 2 and 1 (each within the scatter of the next).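

In this assay, for the compounds shown here, propyl to 3-hydroxypropyl is the first change at this chain to register, with a number 30.1 percentage points lower from compound 2 to compound 3 (beyond the scatter) on the shared core. Measured from the ethyl chain, ethyl to 3-hydroxypropyl gives a number 31.7 percentage points lower from compound 1 to compound 3 (beyond the scatter) and points the same way, so a chain that showed no response to an added methyl does respond once hydroxy stands at its end. No measurement at hand accounts for this drop. Going by these compounds, whether a methoxy or an amine at the chain end would track with hydroxy stays open, as does a longer chain carrying the hydroxy.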